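A few compounds are considered here, and "the series" means these few. Any claim that something is new, unique, unknown or untested is made for them only; others in the source may bear on it.

Measured compounds in the series:
compound 1 `Cc1cc(C(=O)O)nn1-c1ccc(S(=O)(=O)NC(=S)NC2CCCCC2)cc1`, 1%
compound 2 `Cc1cc(C)n(-c2ccc(S(=O)(=O)NC(=S)NCc3ccccc3)cc2)n1`, 0%
compound 3 `C=CCNC(=S)NS(=O)(=O)c1ccc(-n2nc(C)cc2C)cc1`, -1%

In a functional assay on the whole organism (blood, strain albino) with Mus musculus as the target, with stated times of 6 days and 4 h, at a dose of 0.4 mmol/kg by the oral route (a lower number here means less inhibition, a higher number more inhibition at the dose given (going by the name of the read-out)), compound 3 shows the lowest of the three numbers, yet compound 2 and compound 1 both lie within the scatter of it, so the three cannot be told apart. Compound 4 `Cc1cc(C)n(-c2ccc(S(=O)(=O)NC(=S)NC3CCCCC3)cc2)n1` differs from compound 3 by cyclohexyl in place of allyl on an amide-type nitrogen. Within the data shown here, the one measured step at this amide-type nitrogen, a number 1 percentage points lower from compound 2 to compound 3 (within the scatter), stayed within the scatter. Compound 1 bears cyclohexyl on an amide-type nitrogen of a different core and gives 1% in this assay, again near zero. For compound 4, therefore, no step beyond the scatter is expected: a number 2 percentage points higher from compound 3 to compound 4 (within the scatter). Compound 4 is estimated at 1%, with a range from -8% to 10%.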

Compound 4, a percentage reported as inhibition, in the whole organism at one dose (the size of the read-out at that dose, not a potency): < 2%
Compound 4 ended at the assay's limit; the forecaster's own chance of this, stated with the estimate: 0%; the middle value does not contradict the limit.
By their numbers in this assay, from the lowest: compounds 3, 2 and 1 (each within the scatter of the next).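

In this assay compound 4 gives < 2%, which is a limit of the assay, and the steps to it from compound 1, compound 2 and compound 3 cannot be read. The compounds shown leave open whether any group on the amide-type nitrogen moves this read-out beyond the scatter.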